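The source may report more compounds than this note shows. Statements on the series, on what has been measured and on what is new or still open speak of the compounds shown alone.

For the measured compounds named here, compound 1, `O=S(=O)(c1ccc(F)cc1)c1cnc2cc(F)ccc2c1-c1cccc(F)c1`, is one of two compounds measured in an ADME assay on microsomes from liver (Homo sapiens) for metabolic stability, tested at 2.5 uM (a higher number here means faster removal of the compound, a lower number slower removal), and in that assay compound 1 gives 0.95 mL/min, the lowest of the two numbers. Going by the values given here, its only measured neighbour is compound 2, `COc1ccc(S(=O)(=O)c2cnc3cc(F)ccc3c2-c2cccc(F)c2)cc1Cl`, which gives 2.08 mL/min in this assay; the step of a 2.2-fold higher number from compound 1 to compound 2 (0.34 log units; beyond the scatter) follows a change at the sulfonyl sulfur, where a 3-chloro-4-methoxyphenyl stands in place of a 4-fluorophenyl.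

Compound 3, `COc1ccc(-c2c(S(=O)(=O)c3ccc(F)cc3)cnc3cc(F)ccc23)cc1`, has not yet been measured. It differs from compound 1 in this way: 4-methoxyphenyl in place of 3-fluorophenyl on an aromatic carbon. Among the compounds with values here, no measured step touches this aromatic carbon, so the only guidance is that the one change that put a methoxyphenyl group into the molecule, from compound 1 to compound 2, gave a modest rise in this assay, and that change sat on a different part of the molecule. A rise of similar or smaller size is therefore expected, though a result within the scatter would not surprise. Compound 3 is estimated to give 1.4 mL/min in this assay, between 0.8 mL/min and 2.6 mL/min, which means an expected step of a 1.5-fold higher number from compound 1 to compound 3 (0.17 log units; within the scatter).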

Compound 3, intrinsic clearance in a liver preparation (reported as CLH), per the amount of preparation that the assay uses: 1.77 mL/min
Estimate against measurement, compound 3: 1.3-fold (0.10 log units) below, within the range that was stated.
By their numbers in this assay, from the lowest: compounds 1, 3 and 2 (each within the scatter of the next, the first and the last beyond it).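

For the compounds shown here, this is the first measured change at this aromatic carbon, and in this assay putting 4-methoxyphenyl in place of 3-fluorophenyl gives a 1.9-fold higher number from compound 1 to compound 3 (0.27 log units; within the scatter) and so cannot be told apart from repeat measurements. At this position, then, one aromatic ring can be exchanged for another carrying a different substituent without a clear shift in this assay, whereas the change at the sulfonyl sulfur gives a 2.2-fold higher number from compound 1 to compound 2 (0.34 log units; beyond the scatter) in the same read-out. No measurement of any property of these groups accompanies the result, so the compounds shown offer no explanation for either step.

The exchange alters both the substituent and its place on the phenyl ring, and the compounds shown do not separate those two changes. Going by these compounds, it also remains open how this aromatic carbon would respond to a plain phenyl, to a phenyl ring bearing an amine or a carboxylic acid, or to a longer alkyl chain in place of the aromatic ring, since a single step within the scatter says nothing about such groups.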